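Hydrazide series: diacyl replacement of the arylamine tail

The compounds below may be only part of what the source reports. "The series", "measured", "known", "first", "only" and "open" are said of these compounds alone.

In a functional assay on MDA-MB-231 cells (Homo sapiens) for antiproliferative activity, read by MTT assay, with a stated time of 24 h (a lower number here means a stronger inhibitor, a higher number a weaker inhibitor), compound 2 `Cc1cccc(NNC(=O)c2cccc(NS(=O)(=O)c3cnc(O)nc3O)c2)c1` reaches only a limit, giving > 20000 nM. Compound 1 `O=C(NNc1ccccc1F)c1ccc(NS(=O)(=O)c2cnc(O)nc2O)cc1` likewise sits at a limit in this assay, with > 20000 nM. Compound 2 thus stands at the limit of > 20000 nM in this assay, at which 2 of the 2 values shown sit, with no numerical value to rank it. Compound 3 `O=C(NNC(=O)c1cccc(NS(=O)(=O)c2cnc(O)nc2O)c1)c1cccc(Cl)c1` is not yet measured. The change is (3-chlorophenyl)carbonyl in place of 3-methylphenyl on an amine nitrogen. Among the compounds with values here, no measured step between compounds is available, so no direction beyond the scatter can be drawn from them. The step that the limit leaves unreadable from compound 2 to compound 3 is expected to be none beyond the scatter. Compound 3 is expected to give 25000 nM, within 8000 nM to 80000 nM.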

Compound 3, half-maximal inhibitory concentration: 3180 nM
The estimate for compound 3 lay 7.9-fold (0.90 log units) above the measured number, and the stated range ends above it.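

In this assay, within the data shown here, (3-chlorophenyl)carbonyl in place of 3-methylphenyl on the amine nitrogen gives an at least 6.2-fold lower number from compound 2 to compound 3 (0.79 log units; beyond the scatter), the first step that can be read. This position therefore affects the read-out, and compound 3 gives the series a numerical value to rank against. The size of the step remains a bound, with compound 2 reaching only a limit: the limit of > 20000 nM in this assay, at which 2 of the 3 values shown sit.

The change adds the carbonyl and swaps methyl for chlorine together, so the share of each remains unresolved. Also open, on these data alone, is how an acetyl group or a plain benzoyl group would read on this nitrogen.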